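The compounds below may be only part of what the source reports. "The series", "measured", "known", "first", "only" and "open" are said of these compounds alone.

Compound 1 `COc1ccc(-c2noc(C3CCCN3)n2)cc1OC1CCCC1` has been measured in a functional assay on MCF7 cells (Homo sapiens) for antiproliferative activity, read by MTT assay, with a stated time of 24 h; a lower number here means a stronger inhibitor, a higher number a weaker inhibitor. In this assay compound 1 gives > 1000000 nM, which is a limit of the assay and not a number. Compound 2 `Fc1ccc(-c2nc(-c3ccccc3)no2)cc1` gives > 1000000 nM, which is also a limit. Neither compound yields an actual number, so compound 1 has no exact position to start from: the limit of > 1000000 nM in this assay, at which 2 of the 2 values shown sit.

Compound 3 `COc1ccc(-c2noc(-c3ccc(Cl)cc3)n2)cc1OC1CCCC1` keeps the rest of compound 1 and changes one group, with 4-chlorophenyl in place of pyrrolidin-2-yl on an aromatic carbon. Within the data shown here, no measured pair shows what a change of this kind does, so the size of the step in this assay is an informed guess. Compound 2 also lacks the pyrrolidin-2-yl group and gives > 1000000 nM, so a large gain seems unlikely. A modest move towards stronger inhibition is expected at best, and a result that again reaches the limit would be no surprise. The expected change is an at least 3.3-fold lower number from compound 1 to compound 3 (0.52 log units; beyond the scatter). For compound 3 the estimated half-maximal inhibitory concentration is 300000 nM, with an expected range from 30000 nM to 1000000 nM.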

Compound 3, half-maximal inhibitory concentration: 174000 nM
Compound 3: middle estimate off by 1.7-fold (0.24 log units), on the high side; the measured number falls inside the stated range.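

In this assay, among these compounds, compound 3 is the first compound here to give an actual number rather than a limit, so the series now has a measured point for later comparisons. Putting 4-chlorophenyl in place of pyrrolidin-2-yl on this aromatic carbon gives an at least 5.7-fold lower number from compound 1 to compound 3 (0.75 log units; beyond the scatter), which shows that the group at this position can change the read-out by more than the usual scatter. The step can only be stated as a minimum because compound 1 has no exact value, and limits still make up most of the data: the limit of > 1000000 nM in this assay, at which 2 of the 3 values shown sit.

This single exchange cannot separate the contribution of the chlorine from that of the six-membered aromatic ring that carries it, nor show whether the loss of the pyrrolidin-2-yl group plays a part. It also leaves open what other groups would do at this same place, such as a carboxylic acid, an open-chain amine or a phenyl ring bearing a nitrile, and whether any of them would bring the number lower than that of compound 3.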